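The source may hold more compounds than are shown below. What is called first, only, known or untested is meant among the compounds shown, and "the series" means these compounds.

Measured compounds in a functional assay on blood (Homo sapiens), with a stated time of 60 min, in the presence of a further agent that is not named here; a lower number here means that less compound is needed, a higher number that more compound is needed for the effect:
compound 1, `O=S(=O)(c1ccc(Oc2ccc(OC(F)(F)F)cc2)cc1)C1CCC2(CCNCC2)C1`: > 15000 nM
compound 2, `O=C(O)C1(S(=O)(=O)c2ccc(Oc3ccc(OC(F)(F)F)cc3)cc2)CCC2(CCNCC2)C1`: 1800 nM
compound 3, `CN(C)S(=O)(=O)NC(=O)C1(S(=O)(=O)c2ccc(Oc3ccc(OC(F)(F)F)cc3)cc2)CCC2(CCNCC2)C1`: > 15000 nM

The value of compound 1 in this assay is a limit of the assay, not a number, and it shares that limit with compound 3 (the limit of > 15000 nM in this assay, at which 2 of the 3 values shown sit). Compound 4, `COc1ccc(N)c(NC(=O)C2(S(=O)(=O)c3ccc(Oc4ccc(OC(F)(F)F)cc4)cc3)CCC3(CCNCC3)C2)c1`, differs from compound 1 by (2-amino-5-methoxyphenyl)carbamoyl in place of hydrogen on a saturated ring carbon. For the measured compounds named here, two measured steps bear on this change: an at least 8.3-fold lower number from compound 1 to compound 2 (0.92 log units; beyond the scatter), whereas an at least 8.3-fold higher number from compound 2 to compound 3 (0.92 log units; beyond the scatter), showing that a carbonyl carbon bearing a nitrogen substituent rather than hydroxy returns the value to the limit. Compound 4 likewise carries a nitrogen substituent on the carbonyl carbon, so no step beyond the scatter is expected from compound 1 to compound 4 in this assay, and compound 4 is expected to sit at the limit as well. Compound 4 is therefore estimated at 20000 nM, within 5000 nM to 80000 nM, which corresponds to the expected step that the limit leaves unreadable from compound 1 to compound 4.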

Compound 4, half-maximal effective concentration: 3700 nM
Compound 4: the middle estimate sits 5.4-fold (0.73 log units) above what was measured; the measured number lies below the stated range.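

In this assay, a nitrogen substituent on this carbonyl carbon does not by itself return the value to the limit: the (2-amino-5-methoxyphenyl)carbamoyl group gives an at least 4.0-fold lower number from compound 1 to compound 4 (0.60 log units; beyond the scatter). The group on the amide-type nitrogen decides the outcome, as 2-amino-5-methoxyphenyl in place of dimethylsulfamoyl gives an at least 4.0-fold lower number from compound 3 to compound 4 (0.60 log units; beyond the scatter), while (2-amino-5-methoxyphenyl)amino in place of hydroxy gives a 2.1-fold higher number from compound 2 to compound 4 (0.31 log units; beyond the scatter). The first two steps rest on a limit of the assay, not a number: the limit of > 15000 nM in this assay, at which 2 of the 4 values shown sit.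

Open, from the compounds shown here alone, is whether the amino group, the methoxy group or both carry this step, and how a plain phenyl ring or a pyridine ring on that nitrogen would read.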